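This account rests on a few compounds, and the source may have more. Where it says the series, first, only, none or still open, it means among the compounds named here.

Compound 1, with the structure `O=C(C1CCN(C(=O)C(F)(F)F)CC1)N1N=CCC1c1ccccc1`, is the starting point. Among the measured compounds shown here, in a physicochemical assay for lipophilicity, read by HPLC, measured as chromatographic lipophilicity, at pH 7.4 (on this read-out higher numbers stand for higher lipophilicity and lower numbers for lower lipophilicity), compound 1 gives 4.9, which places it second highest among the three compounds that have a number so far. The nearest of the others is compound 2, with the structure `Cc1nnc(N2CCC(C(=O)N3N=CC[C@H]3c3cc(F)cc(F)c3)CC2)o1`; in this assay compound 2 gives 3.6, a gap that is beyond the scatter. Furthest away stands compound 3, with the structure `CC(C)(C)C(=O)n1nccc1-c1ccccc1`, which in this assay gives 8.3, again a gap beyond the scatter. Neither compound 2 nor compound 3 differs from compound 1 in a single place, so their numbers show only where compound 1 lies, not what any one change does.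

Compound 4, with the structure `O=C(c1ccccn1)N1CCC(C(=O)N2N=CCC2c2ccccc2)CC1`, has not yet been measured. It differs from compound 1 in one place: pyridin-2-yl in place of trifluoromethyl on a carbonyl carbon. For the measured compounds named here, no pair of measured compounds shows this change, so the expectation rests on the change itself. A modest fall is expected, estimated as a step of a number 0.50 log units lower from compound 1 to compound 4 (beyond the scatter) in this assay, just beyond the scatter. For compound 4 the estimated value in this assay is 4.4, with a range from 3.7 to 5.1.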

Compound 4, distribution coefficient: 3.1
The estimate for compound 4 lay 1.30 log units above the measured number, outside the stated range (below it).
By their numbers in this assay, from the lowest: compound 4; then compound 2; then compound 1; then compound 3.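

In this assay, putting pyridin-2-yl in place of trifluoromethyl on a carbonyl carbon gives a number 1.80 log units lower from compound 1 to compound 4 (beyond the scatter), a large step and the first in this set that follows a single change. The earlier compounds shown here showed only where compound 1 lay, whereas this pair shows that the group on this carbonyl carbon can by itself shift the number by a large amount, with the rest of the structure held constant. The entering group brings an aromatic ring, a ring nitrogen and a hydrogen-bond acceptor, none of which trifluoromethyl has, and no measurement available here separates these features or explains the size of the step.

A phenyl group or a methyl group on the same carbonyl carbon would help to show whether the step goes with the ring, with its nitrogen or simply with the loss of trifluoromethyl. On these data alone, whether the same exchange gives a step of similar size on a different core also remains open, since this single pair cannot show how far the result extends.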